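This account rests on a few compounds, and the source may have more. Where it says the series, first, only, none or still open, it means among the compounds named here.

Going by the values given here, compound 2 `O=C(COc1ccc(C(=O)/C=C/c2cccc([N+](=O)[O-])c2)cc1)N[C@H]1CCOC1=O` gives 56300 nM in a functional assay on PC-3 cells (Homo sapiens) for antiproliferative activity, read by MTT assay, with a stated time of 72 h (a lower number here means a stronger inhibitor, a higher number a weaker inhibitor), the highest of the two numbers known; the only other, compound 1 `O=C(COc1ccc(C(=O)/C=C/c2ccccc2Cl)cc1)N[C@H]1CCOC1=O`, gives 4610 nM. Among the compounds with values here, the single measured step, a 12-fold higher number from compound 1 to compound 2 (1.09 log units; beyond the scatter), puts the 3-nitrophenyl compound at the weaker end. Compound 3 `O=C(COc1ccc(C(=O)/C=C/c2cccc(F)c2)cc1)N[C@H]1CCOC1=O` differs from compound 2 by fluoro in place of nitro on an aromatic carbon. Within the data shown here, no measured step covers this exchange directly. Compound 3 is nonetheless expected to move downward by a 4.7-fold lower number from compound 2 to compound 3 (0.67 log units; beyond the scatter) because a 12-fold higher number from compound 1 to compound 2 (1.09 log units; beyond the scatter) shows the nitro-bearing compound 2 far weaker than compound 1. Compound 3 is therefore estimated at 12000 nM, in a range from 3500 nM to 40000 nM.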

Compound 3, half-maximal inhibitory concentration: 23200 nM
Compound 3: the middle estimate sits 1.9-fold (0.29 log units) below what was measured, within the range that was stated.
By their numbers in this assay, from the lowest: compound 1; then compound 3; then compound 2.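

In this assay, fluoro in place of nitro on this aromatic carbon, meta to a large group, gives a 2.4-fold lower number from compound 2 to compound 3 (0.39 log units; beyond the scatter), so the nitro compound is not the only weak one. The 3-fluorophenyl compound still falls short of the 2-chlorophenyl compound, with a 5.0-fold higher number from compound 1 to compound 3 (0.70 log units; beyond the scatter). Nothing measured here accounts for either step. The compounds shown leave open whether the gap to compound 1 follows from the halogen itself or from where it sits, and how an amine or a methoxy group would read on this same carbon.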